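Swapping the amine ring on a nitro-bearing oxindole core

The source may hold more compounds than are shown below. What is called first, only, known or untested is meant among the compounds shown, and "the series" means these compounds.

Compound 1 `COc1cc[nH]c1/C=C1\C(=O)Nc2ccc([N+](=O)[O-])c(N3CC[C@@H](N)C3)c21` gives < 10 nM in a functional assay on MDA-MB-435 cells (Homo sapiens) for antiproliferative activity, read by MTT assay, with a stated time of 5 days; a lower number here means a stronger inhibitor, a higher number a weaker inhibitor; this is a limit of the assay (the limit of < 10 nM in this assay, at which 1 of the 2 values shown sits).
Compound 2 `COc1cc[nH]c1/C=C1\C(=O)Nc2ccc([N+](=O)[O-])c(-n3ccnc3)c21` gives > 30000 nM in this assay; this too is a limit (the limit of > 30000 nM in this assay, at which 1 of the 2 values shown sits).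

Compound 1 stands at the strong end, with the other value shown being a limit as well. Compound 3 `COc1cc[nH]c1/C=C1\C(=O)Nc2ccc([N+](=O)[O-])c(N3CCCC(O)C3)c21` carries 3-hydroxypiperidin-1-yl in place of 3-aminopyrrolidin-1-yl on an aromatic carbon. Among the measured compounds shown here, the only measured step, an at least 3000-fold higher number from compound 1 to compound 2 (3.47 log units; beyond the scatter), replaces the same ring with an aromatic group and is large, so it bears on this change only loosely, as both rings in compounds 1 and 3 are non-aromatic and keep one hydrogen-bond donor. A modest weakening is expected, an at least 2.5-fold higher number from compound 1 to compound 3 (0.39 log units; beyond the scatter). Compound 3 is estimated at 25 nM (range 4 nM to 200 nM).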

Compound 3, half-maximal inhibitory concentration: 250 nM
Compound 3: the middle estimate sits 10-fold (1.00 log units) below what was measured, and the stated range ends below it.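

Replacing 3-aminopyrrolidin-1-yl with 3-hydroxypiperidin-1-yl gives an at least 25-fold higher number from compound 1 to compound 3 (1.39 log units; beyond the scatter), so a non-aromatic ring with unchanged hydrogen-bond donor and acceptor counts does not by itself keep the strength of compound 1. Replacing 1H-imidazol-1-yl with the same ring gives an at least 120-fold lower number from compound 2 to compound 3 (2.07 log units; beyond the scatter), which places compound 3 on a measured value between the two ends. Compound 1 and compound 2 each stand at a limit of this assay, so both steps are bounds.

Ring size and the change from amine to hydroxyl move together here, and the compounds shown leave open which carries the loss. A 3-aminopiperidin-1-yl or a 3-hydroxypyrrolidin-1-yl group would separate the two.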